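The source may hold more compounds than are shown below. What is called first, only, known or untested is meant among the compounds shown, and "the series" means these compounds.

Compound 1 `O=C(Nc1cccc(-n2cc(-c3ccncc3)c(-c3ccc(Cl)c(O)c3)n2)c1)Nc1cccc(C(F)(F)F)c1` gives 7900 nM in a functional assay on COLO 205 cells (Homo sapiens) for inhibition, read by sulforhodamine B assay, with a stated time of 48 h; on this read-out lower numbers stand for stronger inhibition of growth and higher numbers for weaker inhibition of growth.
Compound 2 `COc1cc(-c2nn(-c3cccc(NC(=O)c4cccc(C(F)(F)F)c4)c3)cc2-c2ccncc2)ccc1Cl` gives 1640 nM in this assay.
Compound 3 `COc1cc(-c2nn(-c3cccc(NC(=O)Nc4ccc(Cl)c(Cl)c4)c3)cc2-c2ccncc2)ccc1Cl` gives 937 nM in this assay.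

Compound 3 shows the lowest number of the three, though its separation from compound 2, which is a 1.8-fold lower number from compound 2 to compound 3 (0.24 log units; within the scatter), lies within the scatter; only the gap to compound 1 is beyond it. Compound 4 `O=C(Nc1cccc(-n2cc(-c3ccncc3)c(-c3ccc(Cl)c(O)c3)n2)c1)Nc1ccc(Cl)c(Cl)c1` is not yet measured. It differs from compound 3 by hydrogen in place of methyl on an oxygen on an aromatic ring. Among the measured compounds shown here, no measured pair isolates this exact change: compound 1 carries the hydroxy and compound 2 the methoxy, but they also differ in the carbonyl-linked group, so their values can only be noted side by side, with compound 1 the weaker of the two by a margin beyond the scatter. For the measured compounds named here, the one clean step, from compound 2 to compound 3, concerns a different position. Taking the weaker showing of compound 1 as the nearest guide, compound 4 is expected to give a higher number than compound 3, a step of about a 3.7-fold higher number from compound 3 to compound 4 (0.57 log units; beyond the scatter), with wide uncertainty. The estimate for compound 4 is 3500 nM, in a range from 1200 nM to 10000 nM.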

Compound 4, concentration for 50% growth inhibition: 3960 nM
Estimate against measurement, compound 4: 1.1-fold (0.05 log units) below; the range from low to high includes it.
By their numbers in this assay, from the lowest: compounds 3 and 2 (each within the scatter of the next); then compounds 4 and 1 (each within the scatter of the next).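

The change of methoxy to hydroxy, 4-chloro-3-methoxyphenyl to 4-chloro-3-hydroxyphenyl, can now be read by itself in this assay and gives a 4.2-fold higher number from compound 3 to compound 4 (0.63 log units; beyond the scatter) with nothing else altered. With the hydroxy held fixed, 3,4-dichlorophenyl in place of 3-(trifluoromethyl)phenyl on the amide-type nitrogen gives a 2.0-fold lower number from compound 1 to compound 4 (0.30 log units; within the scatter) and so does not separate the two hydroxy compounds. Nothing in the data shown accounts for the step at this oxygen.

Going by these compounds, it remains open whether the step keeps its size with 3-(trifluoromethyl)phenyl on the amide-type nitrogen instead of 3,4-dichlorophenyl. Also open, on these data alone, is how an ethyl group or a longer chain on this oxygen, or an amine in place of the hydroxy, would read against the methoxy of compound 3.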